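The compounds below may be only part of what the source reports. "The series", "measured", "known", "first", "only" and "open" are said of these compounds alone.

In a functional assay on L1210 cells (Mus musculus) for inhibition (on this read-out higher numbers stand for weaker inhibition and lower numbers for stronger inhibition), compound 1 `CC(=O)CC1C[C@@H](CCCCCCCC#C[C@@H](O)COCCOC[C@@H](O)c2ccccc2)OC1=O` gives 19800 nM, while compound 2 `CC(=O)CC1C[C@@H](CCCCCCCC#C[C@H](O)COCCOC[C@H](O)c2ccc3ccccc3c2)OC1=O` gives 3000 nM. Compound 2 therefore holds the lower of the two numbers, and its gap to compound 1 lies beyond the usual scatter. The next compound, compound 3 `CC(=O)CC1C[C@@H](CCCCCCCC#C[C@@H](O)COCCOC[C@@H](O)c2ccc3ccccc3c2)OC1=O`, keeps the same atoms and bonds as compound 2 and differs only in how its stereocentres are drawn: the two compounds have the same atoms and bonds; at least one stereo element is drawn with a configuration in one of them and without one in the other: 2 of 4 stereo elements differ; a stereocentre at a saturated chain carbon is drawn S in compound 2 and R in compound 3; a stereocentre at a saturated chain carbon is drawn R in compound 2 and S in compound 3. Going by the values given here, no measured pair shows a change of this kind, so the size of this step remains open. The expectation therefore starts from compound 2 at 3000 nM, and no step beyond the scatter is expected, with any small shift more likely toward a higher number. The expected step is a 1.2-fold higher number from compound 2 to compound 3 (0.07 log units; within the scatter). For compound 3, the estimated value is 3500 nM, with an expected range of 1200 nM to 10000 nM.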

Compound 3, half-maximal inhibitory concentration: 2100 nM
Compound 3: the middle estimate sits 1.7-fold (0.22 log units) above what was measured; low and high end bracket the measured number.
By their numbers in this assay, from the lowest: compounds 3 and 2 (each within the scatter of the next); then compound 1.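

In this assay, exchanging the drawn configuration at the two stereocentres at saturated chain carbons gives a 1.4-fold lower number from compound 2 to compound 3 (0.15 log units; within the scatter), so this change in the drawing has no effect that can be told from the scatter. With the configuration kept the same, naphthalen-2-yl in place of phenyl gives a 9.4-fold lower number from compound 1 to compound 3 (0.97 log units; beyond the scatter), which shows the effect of this group exchange as a single change, free of the stereo difference that also separates the first two compounds. The stereo comparison carries one reservation: the fact that one of compounds 2 and 3 is drawn with a defined configuration and the other without, at the place where they differ

The compounds shown leave open how a pyridine ring, a quinoline ring or a cyclohexyl group would read at the place of the naphthalen-2-yl. They also leave open what each of the two stereocentres contributes alone, since the two differ together here.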